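Swapping fluoro for methyl on the pyrazole-borne phenyl ring

The source may hold more compounds than are shown below. What is called first, only, known or untested is meant among the compounds shown, and "the series" means these compounds.

Of the compounds shown here, two of one shared core have been tested so far. Compound 1 `Cc1ccc(NC(=S)NC(=O)c2cn(-c3ccccc3)nc2-c2ccc(C)cc2)cc1` carries a methyl group on both outer phenyl rings, and in a functional assay on NCI-H460 cells (Homo sapiens) for inhibition, read by CCK-8 assay, with a stated time of 48 h (a higher number here means a weaker inhibitor, a lower number a stronger inhibitor), compound 1 gives 3760 nM. Compound 2 `O=C(NC(=S)Nc1ccc(F)cc1)c1cn(-c2ccccc2)nc1-c1ccc(F)cc1` carries a fluoro group on both outer phenyl rings instead, and in this assay compound 2 gives 3240 nM. The two numbers sit side by side, and their gap is within the usual scatter, so neither compound can be called the stronger inhibitor on this evidence.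

Compound 3 `Cc1ccc(-c2nn(-c3ccccc3)cc2C(=O)NC(=S)Nc2ccc(F)cc2)cc1` mixes the two: the change from compound 2 is methyl in place of fluoro on an aromatic carbon, so the ring attached to the shared core now matches compound 1 while the ring on the thiourea end stays as in compound 2. Among the measured compounds shown here, since compound 1 and compound 2 agree within the scatter, there is no measured step that would point in either direction. The expected step of a 1.1-fold higher number from compound 2 to compound 3 (0.03 log units; within the scatter) is therefore none beyond the scatter. Compound 3 is estimated at 3500 nM, in a range from 1700 nM to 7200 nM.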

Compound 3, half-maximal inhibitory concentration: 3980 nM
Compound 3: middle estimate off by 1.1-fold (0.06 log units), on the low side; low and high end bracket the measured number.
By their numbers in this assay, from the lowest: compounds 2, 1 and 3 (each within the scatter of the next).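

Compound 3 separates the two outer rings, which compounds 1 and 2 changed together. On the ring attached to the shared core, with the ring on the thiourea end kept as in compound 2, going from 4-fluorophenyl to 4-methylphenyl in this assay gives a 1.2-fold higher number from compound 2 to compound 3 (0.09 log units; within the scatter) and so makes no difference that can be told from repeat-measurement noise at this position. On the ring at the thiourea end, with methyl held on the other ring, the reverse swap gives a 1.1-fold higher number from compound 1 to compound 3 (0.02 log units; within the scatter) in this assay and is equally unresolved, and no accompanying measurement bears on why these swaps leave the number in the same place.

On these data alone, whether any other group at these positions, such as an amine, a carboxylic acid or a longer chain, would shift the number beyond the scatter remains open. Also open, as far as these compounds go, is whether a change on one ring depends on what the other ring carries.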